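Geometric isomer of compound 1 in the leukotriene receptor assay

The source may report more compounds than this note shows. Statements on the series, on what has been measured and on what is new or still open speak of the compounds shown alone.

Measured so far:
compound 1 `C/C(=C/c1ccc2ccc(Cl)cc2n1)c1cccc(OC(C)C(=O)O)c1` — 495 nM
compound 2 `CCCCSc1ccc2ccc(/C=C/c3cccc(OCC(=O)OC)c3)nc2c1` — 1500 nM

In a functional assay on lung (Cavia porcellus) for binding affinity to cysteinyl leukotriene receptor (Homo sapiens) (on this read-out higher numbers stand for weaker inhibition and lower numbers for stronger inhibition), compound 1 gives 495 nM, the lower of the two numbers; compound 2 gives 1500 nM, a gap beyond the scatter. Compound 3 `C/C(=C\c1ccc2ccc(Cl)cc2n1)c1cccc(OC(C)C(=O)O)c1` is not yet measured. It differs from compound 1 only in drawn geometry: the two compounds have the same atoms and bonds; at least one stereo element is drawn with a configuration in one of them and without one in the other: 1 of 2 stereo elements differ; a double bond is drawn Z in compound 1 and E in compound 3. Within the data shown here, no measured pair in this set isolates such a change, so its size is unknown. A swap of double-bond geometry can move this read-out clearly in either direction; the expected step from compound 1 to compound 3 is a 1.8-fold higher number from compound 1 to compound 3 (0.26 log units; within the scatter), towards a somewhat higher number. Compound 3 is estimated at 900 nM, within 200 nM to 4000 nM.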

Compound 3, half-maximal inhibitory concentration: 1780 nM
Compound 3: the middle estimate sits 2.0-fold (0.30 log units) below what was measured; the range from low to high includes it.
By their numbers in this assay, from the lowest: compound 1; then compounds 2 and 3 (each within the scatter of the next).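

In this assay, a change of double-bond geometry alone moves the read-out beyond the scatter (a 3.6-fold higher number from compound 1 to compound 3 (0.56 log units; beyond the scatter)). Among these compounds, no earlier pair isolated this change; atoms and bonds stay the same here, so the Z form drawn in compound 1 gives the stronger inhibition of the two. The pair differs only in stereo drawing: the fact that one of compounds 1 and 3 is drawn with a defined configuration and the other without, at the place where they differ

On these data alone, whether the same preference for the Z form holds with a tetrazole in place of the carboxylic acid remains open. The contribution of the second stereo element also remains unresolved.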